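Swapping the Amide Aryl Group: Predicting Compound 4

The compounds below may be only part of what the source reports. "The series", "measured", "known", "first", "only" and "open" are said of these compounds alone.

In a functional assay on HepG2 cells (Homo sapiens) for inhibition, read by MTT assay (a lower number here means a stronger inhibitor, a higher number a weaker inhibitor), compound 1 `COc1cc2ncnc(Nc3ccc(NC(=O)c4ccccc4C)cc3)c2cc1OC` gives 15000 nM, the highest of the two plain numbers recorded here. Its nearest neighbour is compound 3 `COc1cc2ncnc(Nc3ccc(NC(=O)c4ccccc4F)cc3)c2cc1OC`, which gives 13000 nM, and the two lie within the scatter of each other, as the step of a 1.2-fold lower number from compound 1 to compound 3 (0.06 log units; within the scatter) shows. Compound 2 `COc1cc2ncnc(Nc3ccc(NC(=O)c4ccccc4OC)cc3)c2cc1OC` reaches only a limit of the measurement, > 100000 nM, which is not a number (the limit of > 100000 nM in this assay, at which 1 of the 3 values shown sits). The steps of an at least 6.6-fold higher number from compound 1 to compound 2 (0.82 log units; beyond the scatter) and an at least 7.6-fold lower number from compound 2 to compound 3 (0.88 log units; beyond the scatter) show that replacing methyl or fluoro by methoxy on this aromatic carbon gives a clearly higher number, while methyl and fluoro give numbers within the scatter of each other.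

Compound 4 `COc1cc2ncnc(Nc3ccc(NC(=O)c4ccc(C(F)(F)F)cc4)cc3)c2cc1OC` differs from compound 1 by 4-(trifluoromethyl)phenyl in place of 2-methylphenyl on a carbonyl carbon. For the measured compounds named here, none of the measured steps moves the substituent to a different place on this ring or introduces a trifluoromethyl, so they bear only loosely on this change; they show that small changes on this ring can leave the number unchanged or raise it. A step no larger than the scatter is therefore expected, no change at the digits printed from compound 1 to compound 4 (within the scatter). Compound 4 is estimated to give 15000 nM, with a likely range from 4000 nM to 60000 nM.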

Compound 4, half-maximal inhibitory concentration: > 100000 nM
Compound 4 was reported as a limit; the forecaster's own chance of this, stated with the estimate: 15%; middle value at least 6.6-fold (0.82 log units) from the limit.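

Until now, only methoxy had given a clearly higher number on this ring. Compound 4 shows that 4-(trifluoromethyl)phenyl on the carbonyl carbon does so as well in this assay, with an at least 6.6-fold higher number from compound 1 to compound 4 (0.82 log units; beyond the scatter) and an at least 7.6-fold higher number from compound 3 to compound 4 (0.88 log units; beyond the scatter). Compound 2 and compound 4 are each reported as a limit and not a number, so the step between them cannot be read and the two cannot be ranked: the limit of > 100000 nM in this assay, at which 2 of the 4 values shown sit.

This change swaps both the substituent and its place on the ring at once, and the compounds shown do not separate these two parts of the change. Going by these compounds, how an amine or a carboxylic acid on this ring would read also remains open.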